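Swapping the Fused Ring in a Cell Growth Inhibitor

The source may hold more compounds than are shown below. What is called first, only, known or untested is meant among the compounds shown, and "the series" means these compounds.

Compound 3 `CN(c1ccc(Oc2ncnc3ccsc23)cc1)c1nccc(N2CCc3ccccc32)n1` gives the highest number of the three compounds measured in a functional assay on A549 cells (Homo sapiens) for inhibition, read by MTT assay, with a stated time of 72 h (a higher number here means a weaker inhibitor, a lower number a stronger inhibitor), at 20500 nM. Its nearest neighbour, compound 2 `CN(c1ccc(Oc2ncnc3sccc23)cc1)c1nccc(N2CCCCC2)n1`, gives 8790 nM, and compound 1 `CN(c1ccc(Oc2ncnc3ccsc23)cc1)c1nccc(N2CCCCC2)n1` gives 8240 nM. Compound 4 `CN(c1ccc(Oc2ncnc3sccc23)cc1)c1nccc(N2CCc3ccccc32)n1` has not yet been measured; it differs from compound 3 in one place: a group of 9 heavy atoms (6 carbon, 2 nitrogen, 1 sulfur; one five-membered aromatic ring with 1 hetero atom, one six-membered aromatic ring with 2 hetero atoms) in place of a group of 9 heavy atoms (6 carbon, 2 nitrogen, 1 sulfur; one five-membered aromatic ring with 1 hetero atom, one six-membered aromatic ring with 2 hetero atoms), on an oxygen on an aromatic ring. The same exchange has been seen once before, a 1.1-fold higher number from compound 1 to compound 2 (0.03 log units; within the scatter), a change too small to count. The other measured step, a 2.5-fold higher number from compound 1 to compound 3 (0.40 log units; beyond the scatter), concerns a different change and does not bear here. So the expected step is a 1.1-fold higher number from compound 3 to compound 4 (0.03 log units; within the scatter), essentially none beyond the scatter. Compound 4 is therefore estimated at 22000 nM, with a likely range from 11000 nM to 45000 nM.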

Compound 4, half-maximal inhibitory concentration: 19600 nM
For compound 4 the middle estimate is 1.1-fold (0.05 log units) above the measured one; the range from low to high includes it.
By their numbers in this assay, from the lowest: compounds 1 and 2 (each within the scatter of the next); then compounds 4 and 3 (each within the scatter of the next).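

In this assay the exchange of the two fused groups on the oxygen again makes no difference that can be told apart, a 1.0-fold lower number from compound 3 to compound 4 (0.02 log units; within the scatter), so this finding no longer rests on a single pair: the same change on two cores in this assay, a 1.1-fold higher number (0.03 log units; within the scatter) from compound 1 to compound 2 and a 1.0-fold lower number (0.02 log units; within the scatter) from compound 3 to compound 4, 1.1-fold (0.05 log units) apart, within the scatter of two such steps. The step from piperidin-1-yl to 2,3-dihydro-1H-indol-1-yl also holds with the other fused group, a 2.2-fold higher number from compound 2 to compound 4 (0.35 log units; beyond the scatter): the same change on two cores in this assay, a 2.5-fold higher number (0.40 log units; beyond the scatter) from compound 1 to compound 3 and a 2.2-fold higher number (0.35 log units; beyond the scatter) from compound 2 to compound 4, 1.1-fold (0.05 log units) apart, within the scatter of two such steps. Across these four compounds, the two changes thus act independently of each other.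

Still open, as far as these compounds go, is whether morpholin-4-yl or dimethylamino in place of piperidin-1-yl on the aromatic carbon would give a lower number.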